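The source may hold more compounds than are shown below. What is called first, only, known or untested is meant among the compounds shown, and "the series" means these compounds.

Measured compounds in an assay on isolated protein for inhibition of coagulation factor X (Oryctolagus cuniculus), tested at 1 uM; on this read-out lower numbers stand for less inhibition and higher numbers for more inhibition at the one concentration tested (going by the name of the read-out):
Compound 1 `O=C1[C@@H](NS(=O)(=O)c2nc3cc(Cl)ccc3[nH]2)CCN1Cc1cc2c[nH]ccc-2n1` gives 31%
Compound 2 `Cc1c(S(=O)(=O)N[C@H]2CCN(Cc3cc4cc[nH]cc-4n3)C2=O)sc2ccc(Cl)cc12` gives 52%
Compound 3 `O=C1[C@@H](NS(=O)(=O)c2nc3cc(Cl)ccc3[nH]2)CCN1Cc1cc2[nH]cccc-2n1` gives 14%

Among these three numbers compound 1 stands second highest: compound 3 lies closest to it, and compound 2 is furthest from it, with its higher number. Among the compounds with values here, the one step between compounds differing in a single place is a number 17 percentage points lower from compound 1 to compound 3 (beyond the scatter), a swap of one tail on the saturated chain carbon bound to the amide-type nitrogen in the ring for another; this step does not touch the sulfonyl side of the molecule.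

Compound 4 `O=C1[C@@H](NS(=O)(=O)c2cc3ccc(Cl)nc3s2)CCN1Cc1cc2c[nH]ccc-2n1` differs from compound 1 as follows: a group of 10 heavy atoms (7 carbon, 1 nitrogen, 1 sulfur, 1 chlorine; one five-membered aromatic ring with 1 hetero atom, one six-membered aromatic ring with 1 hetero atom) in place of a group of 10 heavy atoms (7 carbon, 2 nitrogen, 1 chlorine; one five-membered aromatic ring with 2 hetero atoms, one six-membered aromatic ring of carbon only), on a sulfonyl sulfur. Within the data shown here, no measured pair isolates a change on the sulfonyl sulfur; compound 2 carries a different sulfonyl group, but it also differs from compound 1 at the tail, so its higher number cannot be assigned to either change. Among the measured compounds shown here, with no step that bears on this position, the size and direction of the change from compound 1 to compound 4 cannot be read from the data, and the expected step of a number 1 percentage points higher from compound 1 to compound 4 (within the scatter) is taken to be none beyond the scatter. Compound 4 is therefore estimated at 32%, with a range from 10% to 58%.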

Compound 4, a percentage reported as inhibition, at one concentration (the size of the read-out at that concentration, not a potency): 51%
Compound 4: the middle estimate sits 19 percentage points below what was measured, and the stated range covers the measured number.
By their numbers in this assay, from the lowest: compound 3; then compound 1; then compounds 4 and 2 (each within the scatter of the next).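

With the tail held constant, the swap on the sulfonyl sulfur of the 5-chloro-1H-benzimidazol-2-yl group for the chlorinated sulfur-containing bicyclic group gives, in this assay, a number 20 percentage points higher from compound 1 to compound 4 (beyond the scatter) and so shows that this position moves the read-out, which the earlier step, confined to the tail, could not show. The swap alters the ring atoms and the hydrogen-bond donor and acceptor counts at once, so this single step cannot assign the rise to any one of these differences. No measurement shown here accounts for the rise.

Going by these compounds, it remains open whether the same sulfonyl group would raise the number on the tail of compound 3. Within the data shown here, it is also open how much the chlorine contributes, as no compound here carries a bromine or a methyl group in its place.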